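This account rests on a few compounds, and the source may have more. Where it says the series, first, only, none or still open, it means among the compounds named here.

In an ADME assay on microsomes from liver (Homo sapiens) for metabolic stability (a higher number here means faster removal of the compound, a lower number slower removal), compound 1 `CC(C)n1nc(-c2ccnc3[nH]c(C4CCN(CC(=O)N(C)C)CC4)cc23)ccc1=O` gives 13 uL/min, the highest of the two numbers obtained. Compound 3 `COc1cc(F)ccc1-c1ccnc2[nH]c(C3CCOCC3)cc12` gives 10 uL/min in this assay, a reading that sits within the usual scatter of the reading of compound 1, so no order between these two can be claimed. Compound 2 `CC(C)n1cc(-c2ccnc3[nH]c(C4CCNCC4)cc23)ccc1=O` gives < 3 uL/min in this assay, which is a limit of the assay rather than a number (the limit of < 3 uL/min in this assay, at which 1 of the 3 values shown sits). Compound 4 `CC(C)n1cc(-c2ccnc3[nH]c(C4CCN(CC(=O)N(C)C)CC4)cc23)cnc1=O` has not yet been measured in this assay. It differs from compound 1 in one place: a group of 10 heavy atoms (7 carbon, 2 nitrogen, 1 oxygen; one six-membered aromatic ring with 2 hetero atoms) in place of a group of 10 heavy atoms (7 carbon, 2 nitrogen, 1 oxygen; one six-membered aromatic ring with 2 hetero atoms), on an aromatic carbon, on an aromatic carbon of a six-membered aromatic ring with one nitrogen, part of a fused or bridged system of two rings. Since the group that leaves and the group that enters have the same atoms, joined differently, the step in this assay a 1.1-fold lower number from compound 1 to compound 4 (0.03 log units; within the scatter) is expected to be small, within the scatter, in no particular direction. Compound 4 is therefore estimated to give 12 uL/min in this assay, with a range from 6 uL/min to 25 uL/min.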

Compound 4, intrinsic clearance in a liver preparation (reported as CLH), per the amount of preparation that the assay uses: 24 uL/min
Compound 4: the middle estimate sits 2.0-fold (0.30 log units) below what was measured; measured number inside the range.
By their numbers in this assay, from the lowest: compounds 3, 1 and 4 (each within the scatter of the next, the first and the last beyond it). At a limit, below all of these: compound 2.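

Among the compounds shown here, the step of a 1.8-fold higher number from compound 1 to compound 4 (0.27 log units; within the scatter) gives the first comparison at this position in which only one group differs, on an aromatic carbon, opposite the ring nitrogen. In this assay, rearranging the same atoms within the six-membered aromatic ring with 2 hetero atoms gives two readings that cannot be told apart, so this particular exchange shows no effect beyond the scatter. No information given here bears on why the two readings stand where they do.

The compounds shown leave open whether a ring with a different make-up at this position, such as a plain phenyl ring, would stay within the scatter of compound 1. They also leave open what a methyl group or a cyclopropyl group on the ring nitrogen, in place of the isopropyl group, would give.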